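Enantiomer of compound 2: inverting the benzylic stereocentre

The compounds below may be only part of what the source reports. "The series", "measured", "known", "first", "only" and "open" are said of these compounds alone.

Series of aminothiazole propylguanidine derivatives tested in a functional assay on Right cardiac atrium for agonist activity at histamine H2 receptor (Cavia porcellus), with a stated time of 30 min, in the presence of a further agent that is not named here; on this read-out lower numbers stand for an effect already at smaller amounts and higher numbers for an effect only at larger amounts of compound. Compound 1 `Cc1nc(N)sc1CCCN/C(N)=N/C(=S)NC(c1ccccc1)c1ccccc1` gives 66.1 nM. Compound 2 `Cc1nc(N)sc1CCCN/C(N)=N/C(=O)N[C@@H](C)c1ccccc1` gives 23.4 nM, the lowest of the three numbers; compound 3 `COc1ccc(C(C)NC(=O)/N=C(\N)NCCCc2sc(N)nc2C)cc1` gives 38 nM, which lies within the scatter of compound 2, so no order between these two can be drawn, while the gap to compound 1 lies beyond it.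

Compound 4 `Cc1nc(N)sc1CCCN/C(N)=N/C(=O)N[C@H](C)c1ccccc1` is to be measured in this assay. Its relation to compound 2: the two compounds have the same atoms and bonds and differ only in configuration as drawn: 1 of 2 stereo elements differ; a stereocentre at a saturated chain carbon is drawn S in compound 2 and R in compound 4. Among the compounds with values here, no measured pair in this set separates the two configurations, so the direction of the step is open; mirror-image pairs may differ by little or by much. A modest loss is expected, a 2.1-fold higher number from compound 2 to compound 4 (0.33 log units; beyond the scatter), with wide uncertainty. Compound 4 is thus estimated at 50 nM, range 15 nM to 200 nM.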

Compound 4, half-maximal effective concentration: 7.59 nM
The estimate for compound 4 lay 6.6-fold (0.82 log units) above the measured number; the measured number lies below the stated range.
By their numbers in this assay, from the lowest: compound 4; then compounds 2, 3 and 1 (each within the scatter of the next, the first and the last beyond it).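

In this assay the stereocentre at a saturated chain carbon proves to matter, with a 3.1-fold lower number from compound 2 to compound 4 (0.49 log units; beyond the scatter) on going from S to R as drawn. Within the data shown here, the earlier compounds separated no configurations, so this is the first direction available at this position. The step can be assigned to configuration alone because nothing else changes: the fact that compounds 2 and 4 differ only in the configuration as drawn

From the compounds shown here alone, whether the same preference holds for compound 3, drawn without a defined configuration, stays open. Also open, going by these compounds, is what an ethyl group or a carboxylic acid in place of the methyl at this carbon would do.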